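Changing one group on compound 3

The compounds below may be only part of what the source reports. "The series", "measured", "known", "first", "only" and "open" are said of these compounds alone.

Compound 1 `N#Cc1ccc(S(=O)(=O)NC(CC(=O)O)c2ccccc2)cc1` gives 59300 nM
Compound 2 `O=C(O)CC(NS(=O)(=O)c1ccccc1)c1ccc(Cl)cc1Cl` gives 59000 nM
Compound 3 `O=C(O)CC(NS(=O)(=O)c1ccc(C(F)(F)F)cc1)c1ccc(Cl)cc1Cl` gives 37600 nM

In a functional assay on MDA-MB-436 cells (Homo sapiens) for antiproliferative activity, read by MTT assay, with a stated time of 24 h (on this read-out higher numbers stand for weaker inhibition and lower numbers for stronger inhibition), compound 3 gives 37600 nM and stands within the usual scatter of both other compounds. The next compound, compound 4 `N#Cc1ccc(S(=O)(=O)NC(CC(=O)O)c2ccc(Cl)cc2Cl)cc1`, has cyano in place of trifluoromethyl on an aromatic carbon. One measured step involves the same place on the ring, and it shows a 1.6-fold lower number from compound 2 to compound 3 (0.20 log units; within the scatter) with trifluoromethyl in place of hydrogen. Compound 1 also carries cyano and gives 59300 nM, although its core differs from that of compound 4. That value lies within the scatter of compound 3, so the data give no sign of a large change, and no step beyond the scatter is expected in this assay. The estimate is a 1.2-fold higher number from compound 3 to compound 4 (0.08 log units; within the scatter) as the expected step. For compound 4 the expected value is 45000 nM, with an estimated range from 24000 nM to 85000 nM as its limits.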

Compound 4, half-maximal inhibitory concentration: 19800 nM
The estimate for compound 4 lay 2.3-fold (0.36 log units) above the measured number; the measured number lies below the stated range.
By their numbers in this assay, from the lowest: compounds 4, 3, 2 and 1 (each within the scatter of the next, the first and the last beyond it).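

In this assay the swap of trifluoromethyl for cyano on this aromatic carbon gives a 1.9-fold lower number from compound 3 to compound 4 (0.28 log units; within the scatter) and so does not separate the two groups. Against hydrogen at this place, however, cyano gives a 3.0-fold lower number from compound 2 to compound 4 (0.47 log units; beyond the scatter) as a modest step beyond the scatter, which the earlier step with trifluoromethyl, a 1.6-fold lower number from compound 2 to compound 3 (0.20 log units; within the scatter), did not reach. With cyano in place, 2,4-dichlorophenyl in place of phenyl on the saturated chain carbon also gives a modest step, a 3.0-fold lower number from compound 1 to compound 4 (0.48 log units; beyond the scatter), and no measurement available here accounts for either step.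

From the compounds shown here alone, whether an amine or a methoxy group at this aromatic carbon would lie closer to hydrogen or to cyano stays open. So does whether the step from hydrogen to cyano would have the same size on the core of compound 1.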